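A Chloro Step From the Higher of Two Compounds

This account rests on a few compounds, and the source may have more. Where it says the series, first, only, none or still open, it means among the compounds named here.

In a functional assay on HL-60 cells (Homo sapiens) for inhibition, read by MTT assay, with a stated time of 48 h, tested at 10 uM (on this read-out lower numbers stand for less inhibition of growth and higher numbers for more inhibition of growth at the one concentration tested), compound 1 (`Cc1cc(=O)c2c(O)c(CN3CCC(N4CCCCC4)CC3)c(O)c([C@H]3CCN(C)C[C@H]3O)c2o1`) gives 34% and compound 2 (`CN1CC[C@H](c2c(O)cc(O)c3c(=O)cc(/C=C/c4ccccc4)oc23)[C@H](O)C1`) gives 91% as the higher of the two numbers, with a gap beyond the scatter. Compound 3 (`CN1CC[C@H](c2c(O)cc(O)c3c(=O)cc(/C=C/c4ccc(Cl)cc4)oc23)[C@H](O)C1`) departs from compound 2 by chloro in place of hydrogen on an aromatic carbon with chloro in place of hydrogen on an aromatic carbon. Within the data shown here, no measured pair shows this change, so the expectation is a weak one: in this assay a small fall within the scatter is expected. The estimated move is a number 4 percentage points lower from compound 2 to compound 3 (within the scatter) on this read-out. The estimate for compound 3 is 87% as the expected value, with 70% to 98% as its range.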

Compound 3, percent growth inhibition at one concentration: 58%
Compound 3: middle estimate off by 29 percentage points, on the high side, outside the stated range (below it).
By their numbers in this assay, from the lowest: compound 1; then compound 3; then compound 2.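

Within this assay the change from phenyl to 4-chlorophenyl gives a number 33 percentage points lower from compound 2 to compound 3 (beyond the scatter) and so counts as a large step. This aromatic carbon, para to a large group, is therefore a place where a single chloro in place of hydrogen changes growth inhibition at the one concentration tested. Nothing available here explains the fall.

Going by these compounds, whether the fall is particular to chloro stays open, and fluoro, methoxy or an amine on the same carbon would address that. Also open, on these data alone, is how chloro would read on another carbon of this ring.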